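Chloro in Place of Hydrogen: From Compound 2 to Compound 3

This account rests on a few compounds, and the source may have more. Where it says the series, first, only, none or still open, it means among the compounds named here.

Measured compounds:
compound 1 `COc1ccc(OC)c(-c2cc(-c3ccccc3)nn2-c2ccc(S(N)(=O)=O)cc2)c1` gives 29800 nM in a functional assay on cells (Cancer cell lines, Homo sapiens) for cytotoxicity, read by sulforhodamine B assay, with a stated time of 48 h; on this read-out lower numbers stand for stronger inhibition of growth and higher numbers for weaker inhibition of growth
compound 2 `Oc1ccc(O)c(-c2cc(-c3ccccc3)nn2-c2ccccc2)c1` gives 67300 nM in this assay

Compound 2 stands at the highest of the two numbers, which on this read-out means the weaker inhibition of growth. Its nearest neighbour is compound 1, whose number is lower by a margin beyond the usual scatter. For the measured compounds named here, compound 1 and compound 2 differ in more than one place, so no single step links them and their two values can only be set side by side.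

Compound 3 `Oc1ccc(O)c(-c2cc(-c3ccc(Cl)cc3)nn2-c2ccccc2)c1` has not yet been measured. It differs from compound 2 by chloro in place of hydrogen on an aromatic carbon, a change that reads phenyl to 4-chlorophenyl one bond further out. Going by the values given here, no step of this kind exists among the measured compounds, so there is no basis for expecting more than a small shift in either direction. The expected step from compound 2 to compound 3 is therefore a 1.3-fold lower number from compound 2 to compound 3 (0.13 log units; within the scatter), within the scatter. Compound 3 is estimated at 50000 nM, with a range from 20000 nM to 120000 nM.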

Compound 3, concentration for total growth inhibition: 32000 nM
Beside the measured number, compound 3's estimate is 1.6-fold (0.19 log units) above it, within the range that was stated.
By their numbers in this assay, from the lowest: compounds 1 and 3 (each within the scatter of the next); then compound 2.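

The chloro group, on an aromatic carbon para to a large group, provides the only single-place comparison among the compounds shown: in this assay the change gives a 2.1-fold lower number from compound 2 to compound 3 (0.32 log units; beyond the scatter), a modest gain in growth inhibition that lies beyond the usual scatter. Where the earlier pair could only be set side by side, this step shows that the read-out responds to a change at this position, and that 4-chlorophenyl is accepted where phenyl stood, at the cost of a single added heavy atom. Nothing measured alongside these compounds bears on why the number moved.

The compounds shown leave open whether this gain is particular to chloro or would also appear with another group on the same carbon, such as fluoro, trifluoromethyl, methoxy or an amine. They also leave open whether chloro at this position would produce a step of similar size on the core of compound 1, since that compound has no single-place partner here against which such a change could be read.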